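The compounds below may be only part of what the source reports. "The series", "measured", "known", "first", "only" and "open" are said of these compounds alone.

Compounds measured so far in a functional assay (muscle tissue) with Cavia porcellus as the target; a higher number here means that more compound is needed for the effect, a lower number that less compound is needed
compound 1 `COC(=O)C1=C(C)N=C(C)/C(=C(\O)OC)C1c1ccccc1Cl` gives 2.19 nM
compound 2 `COC(=O)C1=C(C)N=C(C)/C(=C(\O)OC)C1c1ccccc1C#N` gives 15.9 nM
compound 3 `COC(=O)C1=C(C)N=C(C)/C(=C(\O)OC)C1c1cc([N+](=O)[O-])ccc1Cl` gives 30.2 nM

Compound 3 (30.2 nM) lies within the scatter of compound 2 (15.9 nM). Compound 1 (2.19 nM) has a lower number than either of them, and both gaps lie outside the scatter. The next structure, compound 4 `COC(=O)C1=C(C)N=C(C)/C(=C(\O)OC)C1c1cc([N+](=O)[O-])ccc1O`, keeps the shared core and the nitro group of compound 3. It carries hydroxy in place of chloro on an aromatic carbon, ortho to a large group and para to a nitro group (hydroxy in place of chloro on an aromatic carbon).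

Among the compounds with values here, two measured steps bear on this change. The nearer is cyano in place of chloro on an aromatic carbon, a modest step (a 7.3-fold higher number from compound 1 to compound 2 (0.86 log units; beyond the scatter)). Nitro in place of hydrogen on an aromatic carbon is a large step (a 14-fold higher number from compound 1 to compound 3 (1.14 log units; beyond the scatter)) but a different kind of exchange. Within the data shown here, no measured compound carries a hydroxy group, and only one measured step replaces chloro, so the size remains uncertain.

A modest move to a higher number is therefore expected, and the estimated step is a 5.0-fold higher number from compound 3 to compound 4 (0.70 log units; beyond the scatter) in this series. In this assay compound 4 is estimated at 150 nM with an expected range from 30 nM to 800 nM across repeat measurements.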

Compound 4, half-maximal effective concentration: 100 nM
Compound 4: middle estimate off by 1.5-fold (0.18 log units), on the high side; low and high end bracket the measured number.
By their numbers in this assay, from the lowest: compound 1; then compounds 2 and 3 (each within the scatter of the next); then compound 4.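

In this assay, within the data shown here, hydroxy in place of chloro, on the aromatic carbon ortho to a large group and para to a nitro group, gives a 3.3-fold higher number from compound 3 to compound 4 (0.52 log units; beyond the scatter) and is the first measured exchange at this carbon with the nitro group present. Chloro has now been replaced in two pairs, and the number rises in both, as cyano gives a 7.3-fold higher number from compound 1 to compound 2 (0.86 log units; beyond the scatter) and hydroxy gives the step just described, so neither entering group matches chloro in these two pairs. No measurement is available that explains this rise.

The compounds shown leave open whether hydroxy would give a step of similar size on a ring without the nitro group, since the only compound with hydroxy also carries nitro. They also leave open whether a methoxy group, an amine or a fluorine atom at this carbon would raise the number as hydroxy does, which would show whether the rise is specific to hydroxy or follows from the loss of chloro.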